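A Nitrophenyl Addition Carried Over to a Fluoro Analogue

The source may report more compounds than this note shows. Statements on the series, on what has been measured and on what is new or still open speak of the compounds shown alone.

Compound 2 `Cc1ccc(C2=NNC(c3cn(-c4ccccc4)nc3-c3ccc(Cl)c(Cl)c3)C2)cc1` and compound 1 `Cc1ccc(C2=NN(c3ccc([N+](=O)[O-])cc3)C(c3cn(-c4ccccc4)nc3-c3ccc(Cl)c(Cl)c3)C2)cc1` share one core, and compound 1 carries 4-nitrophenyl in place of hydrogen on an amine nitrogen in a ring. In a functional assay on the whole organism (strain Wistar) for inhibition, with Rattus norvegicus as the target, read by paw edema, with stated times of 30 min and 120 min, at a dose of 50 mg/kg by the oral route (on this read-out lower numbers stand for less inhibition and higher numbers for more inhibition at the one dose given (going by the name of the read-out)), compound 2 gives 48.4% and compound 1 gives 71.9%, so that a number 23.5 percentage points higher from compound 2 to compound 1 (beyond the scatter). Compound 3 `Fc1ccc(C2=NNC(c3cn(-c4ccccc4)nc3-c3ccc(Cl)c(Cl)c3)C2)cc1` differs from compound 2 by fluoro in place of methyl on an aromatic carbon; in this assay compound 3 gives 46.1%, and a number 2.3 percentage points lower from compound 2 to compound 3 (within the scatter). Compound 4 `O=[N+]([O-])c1ccc(N2N=C(c3ccc(F)cc3)CC2c2cn(-c3ccccc3)nc2-c2ccc(Cl)c(Cl)c2)cc1` has not been measured; it bears 4-nitrophenyl in place of hydrogen on an amine nitrogen in a ring. This is the same kind of change as that from compound 2 to compound 1, though here the ring atom two ring bonds away bears a 4-fluorophenyl group rather than a 4-methylphenyl group. Because a number 2.3 percentage points lower from compound 2 to compound 3 (within the scatter) lies within the scatter, the step from compound 3 is expected to be a number 22.9 percentage points higher from compound 3 to compound 4 (beyond the scatter). Compound 4 is therefore estimated at 69%, expected to fall between 57% and 80%.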

Compound 4, a percentage reported as inhibition, in the whole organism at one dose (the size of the read-out at that dose, not a potency): 65.6%
Beside the measured number, compound 4's estimate is 3.4 percentage points above it; the range from low to high includes it.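

In this assay, the 4-nitrophenyl group on the ring amine nitrogen gave a number 19.5 percentage points higher from compound 3 to compound 4 (beyond the scatter), so the addition carried over to the second core at a similar size: the same change on two cores in this assay, a number 23.5 percentage points higher (beyond the scatter) from compound 2 to compound 1 and a number 19.5 percentage points higher (beyond the scatter) from compound 3 to compound 4, 4 percentage points apart, within the scatter of two such steps. Fluoro in place of methyl gave a number 6.3 percentage points lower from compound 1 to compound 4 (within the scatter), so this exchange stayed within the scatter with the 4-nitrophenyl group present as well: the same change on two cores in this assay, a number 2.3 percentage points lower (within the scatter) from compound 2 to compound 3 and a number 6.3 percentage points lower (within the scatter) from compound 1 to compound 4, 4 percentage points apart, within the scatter of two such steps. Going by these compounds alone, this rests on only two pairs of compounds at a single dose, and it does not show that the step would hold on other cores or at other doses.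

The compounds shown leave open whether an acetyl group or a plain phenyl on that ring nitrogen would give a step of similar size. They also leave open how a methoxy group in place of the fluoro would behave with the 4-nitrophenyl group present.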